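The source may report more compounds than this note shows. Statements on the series, on what has been measured and on what is new or still open speak of the compounds shown alone.

Of the compounds shown here, two have been measured in a functional assay on MDA-MB-231 cells (Homo sapiens) for antiproliferative activity, read by sulforhodamine B assay, with a stated time of 72 h; on this read-out lower numbers stand for stronger inhibition and higher numbers for weaker inhibition. Compound 1 `CCOC(=O)c1cnc2ccc(-c3cnc(OC)c(NS(C)(=O)=O)c3)cn12` gives 190 nM. Compound 2 `COc1ncc(-c2ccc3ncc(C(=O)NCc4ccncc4)n3c2)cc1NS(=O)(=O)c1ccc(F)cc1F` gives 420 nM; of the two numbers this is the higher one, and the gap to compound 1 lies beyond the usual scatter of the measurement. Compound 3 `COc1ncc(-c2ccc3ncc(C(=O)N4CCC(O)CC4)n3c2)cc1NS(=O)(=O)c1ccc(F)cc1F` has not yet been measured; it is built from compound 2 by a single change at the carbonyl carbon: 4-hydroxypiperidin-1-yl in place of ((pyridin-4-yl)methyl)amino on a carbonyl carbon. For the measured compounds named here, no measured pair isolates this change, so what it does in this assay is open. A step of modest size is expected, without a firm direction, most likely a small move to a higher number. Compound 3 is estimated at 550 nM, in a range from 170 nM to 1800 nM. The expected step from the measured parent is a 1.3-fold higher number from compound 2 to compound 3 (0.12 log units; within the scatter).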

Compound 3, half-maximal inhibitory concentration: 630 nM
Beside the measured number, compound 3's estimate is 1.1-fold (0.06 log units) below it; the measured number falls inside the stated range.
By their numbers in this assay, from the lowest: compound 1; then compounds 2 and 3 (each within the scatter of the next).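

In this assay, the carbonyl carbon accepts an exchange of 4-hydroxypiperidin-1-yl for ((pyridin-4-yl)methyl)amino with a 1.5-fold higher number from compound 2 to compound 3 (0.18 log units; within the scatter), so this assay does not separate the two groups. For the compounds shown here, this is the first pair that isolates a change at this place, and it shows that, in this pair, the aromatic ring of the leaving group can give way to a non-aromatic ring without a change beyond the scatter. Nothing available explains this result.

Plain piperidin-1-yl or morpholin-4-yl on the same carbonyl carbon would test whether the hydroxy group of compound 3 contributes anything, and only such further groups could show how broad this tolerance is. Compound 1 differs from compound 2 and compound 3 in more than one place, so steps to it cannot be read.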